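From 4-aminocyclohexyl to benzyl: an expected step

The source may report more compounds than this note shows. Statements on the series, on what has been measured and on what is new or still open speak of the compounds shown alone.

Measured in a functional assay on MDA-MB-435 cells (Homo sapiens) for cytotoxicity, read by MTT assay, with a stated time of 72 h (on this read-out lower numbers stand for stronger inhibition and higher numbers for weaker inhibition), so far:
- compound 1 `N[C@H]1CC[C@H](Nc2c(C(=O)NCc3ccc(F)cc3)nc(N3CCCCS3(=O)=O)c3cccnc23)CC1` with 5000 nM
- compound 2 `N[C@H]1CC[C@H](Nc2c(C(=O)NCc3ccc(F)cc3)nc(Br)c3cccnc23)CC1` with 6000 nM
- compound 3 `COc1ccc(CNC(=O)c2nc(Br)c3cccnc3c2N[C@H]2CC[C@H](N)CC2)cc1` with 5000 nM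

Compound 2 at 6000 nM lies within the scatter of both other compounds. Compound 4 `O=C(NCc1ccc(F)cc1)c1nc(Br)c2cccnc2c1NCc1ccccc1` is still unmeasured. It departs from compound 2 by benzyl in place of 4-aminocyclohexyl on a nitrogen on an aromatic ring. The two measured steps, a 1.2-fold higher number from compound 1 to compound 2 (0.08 log units; within the scatter) and a 1.2-fold lower number from compound 2 to compound 3 (0.08 log units; within the scatter), both stay within the scatter, but each changes a different place, so neither tests this swap. With no direct evidence, a modest move toward a higher number is expected in this assay, namely a 1.3-fold higher number from compound 2 to compound 4 (0.12 log units; within the scatter), and its direction remains uncertain. The estimate for compound 4 is 8000 nM, with an expected range from 3000 nM to 20000 nM here.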

Compound 4, half-maximal inhibitory concentration: > 20000 nM
Compound 4 was reported as a limit; the forecaster's own chance of this, stated with the estimate: 30%; middle value at least 2.5-fold (0.39 log units) from the limit.
By their numbers in this assay, from the lowest: compounds 1, 3 and 2 (each within the scatter of the next). At a limit, above all of these: compound 4.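

In this assay compound 4 gives > 20000 nM as a limit and not as a number. Benzyl in place of 4-aminocyclohexyl on a nitrogen on an aromatic ring gives an at least 3.3-fold higher number from compound 2 to compound 4 (0.52 log units; beyond the scatter) and is the only step shown that lies beyond the scatter. The earlier changes at other places stayed within the scatter, so this position is the first shown where a change separates two compounds.

Whether the amine or the ring of 4-aminocyclohexyl accounts for this step remains open, and a plain cyclohexyl or a 4-aminobenzyl group would separate the two. From the compounds shown here alone, how far compound 4 lies past its limit also stays open.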